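The compounds below may be only part of what the source reports. "The series", "measured", "known", "first", "only" and "open" are said of these compounds alone.

Series notes on the shared core. In an in vitro functional assay on HEK285-7 cells for antagonist activity at prostaglandin D2 receptor 2 (Homo sapiens), read by BRET and beta-arrestin recruitment (a higher number here means a larger maximal response, a lower number a smaller maximal response), compound 1 `O=C(O)Cc1sc(Cc2ccccc2-c2ccccc2)nc1-c1ccc(Cl)cc1` gives 50%. Compound 2 `COc1cc(-c2nc(C(c3ccc(F)cc3)c3ccc(F)cc3)sc2CC(=O)O)ccn1` gives 60% in this assay, and compound 3 `O=C(O)Cc1sc(C(c2ccc(F)cc2)c2ccc(F)cc2)nc1-c1ccnc(N2CCCC2)c1` gives 80% in this assay. Compound 3 therefore stands highest of the three measured numbers: the nearest is compound 2, lower by a margin beyond the scatter, and the furthest is compound 1, lower by a larger margin, also beyond the scatter. Going by the values given here, the only measured step in the set is a number 20 percentage points higher from compound 2 to compound 3 (beyond the scatter), a modest rise. Compound 4 `NS(=O)(=O)c1ccc(-c2nc(C(c3ccc(F)cc3)c3ccc(F)cc3)sc2CC(=O)O)cc1` carries the change (4-sulfamoylphenyl in place of 2-(pyrrolidin-1-yl)pyridin-4-yl on an aromatic carbon). Among the compounds with values here, no measured step covers this exchange. Compounds 1 and 2, which lack the pyrrolidin-1-yl group, both show lower numbers than compound 3 in this assay. For compound 4 a downward step beyond the scatter is therefore expected, estimated as a number 25 percentage points lower from compound 3 to compound 4 (beyond the scatter). The expected value for compound 4 in this assay is 55%, with a range from 40% to 75%.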

Compound 4, largest response reached (reported as efficacy), in percent of the reference or control that the assay uses: 80%
Compound 4: the middle estimate sits 25 percentage points below what was measured; measured number outside the range, above it.
By their numbers in this assay, from the lowest: compounds 1 and 2 (each within the scatter of the next); then compounds 3 and 4 (each within the scatter of the next).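

In this assay, the aromatic carbon next to the ring nitrogen accepts 4-sulfamoylphenyl in place of 2-(pyrrolidin-1-yl)pyridin-4-yl with no change at the digits printed from compound 3 to compound 4 (within the scatter), so the pyrrolidin-1-yl group is not required for the number held by compound 3. Against the methoxy-bearing group, the same position gives a number 20 percentage points higher from compound 2 to compound 4 (beyond the scatter), alongside a number 20 percentage points higher from compound 2 to compound 3 (beyond the scatter). Two groups with different rings and different substituents therefore read alike here, and the rise over compound 2 does not depend on a ring nitrogen in the entering group. Nothing available explains why these two groups read alike.

The compounds shown leave open how an unsubstituted phenyl or a 4-(methylsulfonyl)phenyl group would read at this position. They also leave open whether 4-sulfamoylphenyl keeps this number when the other large group on the shared core changes.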